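The source may report more compounds than this note shows. Statements on the series, on what has been measured and on what is new or still open speak of the compounds shown alone.

Measured compounds:
- compound 1, `COc1nc2ccc(Br)cc2cc1C(c1ccccc1)n1cc(-c2ccc(Br)cc2)nn1`: 10.4%
- compound 2, `CCCCCCCCc1cn(C(c2ccccc2)c2cc3cc(Br)ccc3nc2OC)nn1`: 12.1%
- compound 3, `COc1nc2ccc(Br)cc2cc1C(c1ccccc1)n1cc(-c2ccc(F)cc2)nn1`: 14.9%

All three were tested in an ADME assay on PANC-1 cells (Homo sapiens) for cytotoxicity, read by sulforhodamine B assay, with a stated time of 48 h, tested at 10 uM; a higher number here means more inhibition at the concentration tested (going by the name of the read-out), a lower number less inhibition. Compound 3 has the highest of the three numbers, but its lead is small: the step of a number 2.8 percentage points higher from compound 2 to compound 3 (within the scatter) and the step of a number 4.5 percentage points higher from compound 1 to compound 3 (within the scatter) both lie within the scatter, so the three numbers can only be called level with one another. The change from compound 1 to compound 2, a number 1.7 percentage points higher from compound 1 to compound 2 (within the scatter), is likewise within the scatter.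

Compound 4, `COc1nc2ccc(Br)cc2cc1C(c1ccccc1)n1cc(CO)nn1`, has not yet been measured in this assay. It differs from compound 3 by hydroxymethyl in place of 4-fluorophenyl on an aromatic carbon, the change sitting on an aromatic carbon of a five-membered aromatic ring with 3 nitrogen. Among the compounds with values here, the steps that bear on this position are the two already seen there: an octyl in place of 4-bromophenyl and a 4-fluorophenyl in place of octyl, both of which left the number within the scatter. A hydroxymethyl at this place is not covered by any measured pair, so the expectation rests only on how little the position has mattered so far.

Compound 4 is therefore expected to stay near compound 3, with a step of a number 2.9 percentage points lower from compound 3 to compound 4 (within the scatter) that is estimated to lie within the scatter. The estimated value for compound 4 is 12%, between 2% and 24%.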

Compound 4, a percentage reported as inhibition, at one concentration (the size of the read-out at that concentration, not a potency): 15%
Compound 4: middle estimate off by 3 percentage points, on the low side; low and high end bracket the measured number.
By their numbers in this assay, from the lowest: compounds 1, 2, 3 and 4 (each within the scatter of the next).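

Replacing the 4-fluorophenyl with a hydroxymethyl removes a six-membered aromatic ring and adds a hydrogen-bond donor and a hydrogen-bond acceptor, yet in this assay the outcome is a number 0.1 percentage points higher from compound 3 to compound 4 (within the scatter) and the two compounds cannot be told apart. Comparisons with the other two compounds point the same way: a number 2.9 percentage points higher from compound 2 to compound 4 (within the scatter) and a number 4.6 percentage points higher from compound 1 to compound 4 (within the scatter) show that this small group bearing a hydroxy sits level with the octyl chain and the 4-bromophenyl at this carbon of the five-membered ring, so the position has now taken groups of very different size and hydrogen-bonding count without a step beyond the scatter. Nothing measured here accounts for this sameness.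

Still open, on these data alone, is whether any group at this carbon can move the number beyond the scatter, for example an amine, a carboxylic acid or a short chain such as ethyl. All four compounds also share the same core and were read at one concentration, so these results cannot say whether the position would stay this undemanding on a different core or at other concentrations.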